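The compounds below may be only part of what the source reports. "The series", "measured", "known", "first", "only" and "open" are said of these compounds alone.

Compound 3 `CC1(C)[C@@H]2CC[C@@]1(CS(=O)(=O)N1CCN(c3ccc(C(F)(F)F)cc3)CC1)C(=O)C2` is one of three compounds already measured. In a functional assay on CHO-K1 cells for antagonist activity at C-X-C chemokine receptor type 3 (Homo sapiens), read by FLIPR and calcium flux (a lower number here means a stronger inhibitor, a higher number a weaker inhibitor), compound 3 reaches only a limit, > 31600 nM, and no number. Compound 3 thus stands at the limit of > 31600 nM in this assay, at which 2 of the 3 values shown sit. Compound 2 `Cc1ccc(N2CCN(S(=O)(=O)C[C@]34CC[C@H](CC3=O)C4(C)C)CC2)nc1` also gives a limit in this assay, > 31600 nM. Compound 1 `CC1(C)[C@@H]2CC[C@@]1(CS(=O)(=O)N1CCN(c3ccc(Br)cn3)CC1)C(=O)C2` gives 1580 nM in this assay, and the steps away from it, an at least 20-fold higher number from compound 1 to compound 2 (1.30 log units; beyond the scatter) and an at least 20-fold higher number from compound 1 to compound 3 (1.30 log units; beyond the scatter), were both large. Compound 4 `CC1(C)[C@@H]2CC[C@@]1(CS(=O)(=O)N1CCN(c3ncc(Br)cn3)CC1)C(=O)C2` is the next to be measured; it differs from compound 3 by 5-bromopyrimidin-2-yl in place of 4-(trifluoromethyl)phenyl on an amine nitrogen in a ring. This change brings back a bromine on an aromatic ring with nitrogen, close to the pattern of compound 1. A large fall is therefore expected, an at least 12-fold lower number from compound 3 to compound 4 (1.10 log units; beyond the scatter), because compound 1 gives 1580 nM. Compound 4 is estimated at 2500 nM, within 800 nM to 12000 nM.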

Compound 4, half-maximal inhibitory concentration: 631 nM
Estimate against measurement, compound 4: 4.0-fold (0.60 log units) above, outside the stated range (below it).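

In this assay, placing 5-bromopyrimidin-2-yl on the ring nitrogen gives an at least 50-fold lower number from compound 3 to compound 4 (1.69 log units; beyond the scatter) and an at least 50-fold lower number from compound 2 to compound 4 (1.69 log units; beyond the scatter). Against the closest active group, 5-bromopyridin-2-yl, it gives a 2.5-fold lower number from compound 1 to compound 4 (0.40 log units; beyond the scatter), so this position accepts more than one bromine-bearing aromatic ring with nitrogen, and the pyrimidine ring gives the stronger inhibitor of the two. Compound 2 and compound 3 each remain at a limit, not a number: the limit of > 31600 nM in this assay, at which 2 of the 4 values shown sit.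

On these data alone, whether the bromine itself is needed on the pyrimidine ring remains open. A chlorine, a nitrile or a methoxy group in its place could give a stronger or a weaker inhibitor.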